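Acetic Acid Side Chain Turned into a Diethylamide

This account rests on a few compounds, and the source may have more. Where it says the series, first, only, none or still open, it means among the compounds named here.

For the measured compounds named here, compound 1 `CCCCc1nc(C)c(CC(=O)O)c(=O)n1Cc1ccc(-c2ccccc2-c2nnn[nH]2)cc1` is the only member of this set with a reported number: in an in vivo functional assay on the whole organism for inhibition, with Rattus norvegicus as the target (a lower number here means that less compound is needed, a higher number that more compound is needed for the effect), compound 1 gives 0.13 mg/kg. Compound 2 `CCCc1nc(C)c(CC(=O)O)c(=O)n1Cc1ccc(-c2ccccc2-c2nnn[nH]2)cc1` belongs to the same series, but in this assay compound 2 shows only "not determined" (no result reported), so no number is available for it. Compound 3 `CCCCc1nc(C)c(CC(=O)N(CC)CC)c(=O)n1Cc1ccc(-c2ccccc2-c2nnn[nH]2)cc1` differs from compound 1 by diethylamino in place of hydroxy on a carbonyl carbon. Going by the values given here, no measured pair here shows such a change, so the step must be estimated: more compound is expected to be needed, with the step from compound 1 to compound 3 estimated at a 4.6-fold higher number from compound 1 to compound 3 (0.66 log units; beyond the scatter). Compound 3 is therefore expected near 0.6 mg/kg, within a range from 0.12 mg/kg to 3 mg/kg.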

Compound 3, dose for half-maximal effect: 0.089 mg/kg
Estimate against measurement, compound 3: 6.7-fold (0.83 log units) above; the measured number lies below the stated range.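

Replacing hydroxy with diethylamino on this carbonyl carbon gives a step in this assay of a 1.5-fold lower number from compound 1 to compound 3 (0.16 log units; within the scatter) and thus no measurable separation between the two compounds. At this position, then, the in vivo dose tolerates the carboxy group giving way to diethylcarbamoyl, with the loss of its hydrogen-bond donor. Nothing measured here explains this result.

The compounds shown leave open how a primary amide, a piperidine amide or a methyl ester would read at this carbonyl carbon. They also leave open whether the diethylamino group would behave alike on the propyl chain of compound 2.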